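Trading pyridin-2-yl for 1,3-thiazol-2-yl on an amide

A few compounds are considered here, and "the series" means these few. Any claim that something is new, unique, unknown or untested is made for them only; others in the source may bear on it.

In a functional assay on MGC-803 cells (Homo sapiens) for inhibition, read by MTT assay, with a stated time of 72 h (a higher number here means a weaker inhibitor, a lower number a stronger inhibitor), compound 2 `O=C(Nc1ccccn1)C1CCN(C/C=C/c2ccccc2)CC1` gives 45200 nM, and compound 1 `N#Cc1ccc(NC(=O)C2CCN(C/C=C/c3ccccc3)CC2)cc1` gives 28200 nM. These two numbers lie within the scatter of each other, so neither compound can be ranked above the other.

Compound 3 `O=C(Nc1nccs1)C1CCN(C/C=C/c2ccccc2)CC1` keeps the core of compound 2 but has 1,3-thiazol-2-yl in place of pyridin-2-yl on an amide-type nitrogen. For the measured compounds named here, only one measured step bears on this change, since it also alters the group on that nitrogen: a 1.6-fold higher number from compound 1 to compound 2 (0.20 log units; within the scatter). A single step is thin evidence, and it involves a different pair of groups. Even so, it gives no reason to expect a change beyond the scatter in this assay. The expected move is a 1.2-fold lower number from compound 2 to compound 3 (0.08 log units; within the scatter). The estimate for compound 3 is 38000 nM, with an expected range from 16000 nM to 90000 nM.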

Compound 3, half-maximal inhibitory concentration: 16400 nM
Estimate against measurement, compound 3: 2.3-fold (0.36 log units) above, and the stated range covers the measured number.
By their numbers in this assay, from the lowest: compounds 3, 1 and 2 (each within the scatter of the next, the first and the last beyond it).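

In this assay, the group on the amide-type nitrogen can shift the number beyond the scatter: 1,3-thiazol-2-yl in place of pyridin-2-yl gives a 2.8-fold lower number from compound 2 to compound 3 (0.44 log units; beyond the scatter), a modest step and the first at this position to clear the scatter. The other new step, with 1,3-thiazol-2-yl in place of 4-cyanophenyl, is a 1.7-fold lower number from compound 1 to compound 3 (0.24 log units; within the scatter), so the separation holds only against pyridin-2-yl and neither of these two compounds can be ranked above the other. Nothing available explains why the five-membered ring gives the lower number.

The compounds shown leave open whether the ring sulfur matters, which a 1,3-oxazol-2-yl group, with oxygen in its place, would help to test. From the compounds shown here alone, all three also carry an aromatic ring on this nitrogen, so how a saturated group such as cyclohexyl would behave remains unknown.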